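The source may hold more compounds than are shown below. What is called first, only, known or untested is meant among the compounds shown, and "the series" means these compounds.

For the measured compounds named here, compound 2 `COc1ccc(/C=C/c2cc(OC)cc(OC)c2/C=C/C(=O)c2cc3ccc(C)cc3oc2=O)cc1` is the one member of the set that has a number in an assay on isolated protein for inhibition of Amine oxidase [flavin-containing] B (Homo sapiens), read by fluorescence, with a stated time of 15 min; a lower number here means a stronger inhibitor, a higher number a weaker inhibitor. In this assay compound 2 gives 2780 nM. Compound 1 `COc1ccc(/C=C/c2cc(OC)cc(OC)c2/C=C/C(=O)c2cc3cc(Br)cc(OC)c3oc2=O)cc1` is reported in this assay only as a limit, > 60000 nM. Going by the values given here, that limit, (the limit of > 60000 nM in this assay, at which 1 of the 2 values shown sits), is the only other evidence on the measured pair; no step between measured compounds is given, so the two values show only that compound 2 has a number while compound 1 sits at a limit.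

Compound 3 `COc1ccc(/C=C/c2cc(OC)cc(OC)c2/C=C/C(=O)c2cc3cc(Br)ccc3oc2=O)cc1` has not yet been measured. It differs from compound 2 by a group of 12 heavy atoms (9 carbon, 2 oxygen, 1 bromine; one six-membered aromatic ring of carbon only, one six-membered aromatic ring with 1 hetero atom) in place of a group of 12 heavy atoms (10 carbon, 2 oxygen; one six-membered aromatic ring of carbon only, one six-membered aromatic ring with 1 hetero atom), on a carbonyl carbon. The bromine it gains is also carried by compound 1, though compound 3 does not carry everything that compound 1 carries.

In this assay a step toward weaker inhibition, larger than the usual scatter, is expected from compound 2 to compound 3, a 3.2-fold higher number from compound 2 to compound 3 (0.51 log units; beyond the scatter), because compound 1 with its bromine sits at the limit of > 60000 nM in this assay, at which 1 of the 2 values shown sits. Compound 3 is therefore estimated to give 9000 nM, with a range of 2000 nM to 45000 nM, and there is a real chance that it too is reported only as a limit.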

Compound 3, half-maximal inhibitory concentration: > 60000 nM
Compound 3 was reported as a limit; the forecaster's own chance of this, stated with the estimate: 25%; middle value at least 6.6-fold (0.82 log units) away from the limit.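

For the compounds shown here, putting the group of 12 heavy atoms with 9 carbon, 2 oxygen and 1 bromine in place of the group of 12 heavy atoms with 10 carbon and 2 oxygen, on a carbonyl carbon, gives an at least 21-fold higher number from compound 2 to compound 3 (1.33 log units; beyond the scatter), the first step in the set that can be read. In this assay compound 3 gives > 60000 nM, which is a limit of the assay and not a number. This single change is therefore enough to take the series from a measured value to that limit, and with compound 1 and compound 3 both at the limit, the step between them, hydrogen in place of methoxy on an aromatic carbon, cannot be read: the limit of > 60000 nM in this assay, at which 2 of the 3 values shown sit.

The compounds shown leave open how far beyond the limit compound 1 and compound 3 lie, and so whether the methoxy group changes anything once the bromine is present. They also do not tell whether a chlorine, a fluorine or an amine carried on the same ring in place of the bromine would keep a measurable value in this assay.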